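This account rests on a few compounds, and the source may have more. Where it says the series, first, only, none or still open, it means among the compounds named here.

In a functional assay on HL-60 cells (Homo sapiens) for antiproliferative activity (on this read-out higher numbers stand for weaker inhibition and lower numbers for stronger inhibition), compound 3 (`COC(=O)c1ccc(Oc2ccc(OC)cc2)c(I)c1`) gives > 20000 nM, which is a limit and not a number. Compound 1 (`COC(=O)c1ccc(Oc2ccc(OC)c(OC)c2)c([N+](=O)[O-])c1`) gives > 20000 nM, also a limit. Compound 2 (`COC(=O)c1ccc(Oc2ccc(OC)c(OC)c2)c(N)c1`) gives > 20000 nM, again a limit. The whole picture so far is the limit of > 20000 nM in this assay, at which 3 of the 3 values shown sit. Compound 4 (`COC(=O)c1ccc(Oc2ccc(OC)c(OC)c2)c(I)c1`) differs from compound 3 as follows: methoxy in place of hydrogen on an aromatic carbon. Going by the values given here, the only measured step, a step that the two limits leave unreadable from compound 1 to compound 2, has no readable size and involves a different change, so it offers no guide. Among the compounds with values here, with no measured compound yet below the limit, no clear gain is expected. The expected step is a number no higher from compound 3 to compound 4 (the limit leaves the size open). For compound 4 the estimated value is 20000 nM, with an expected range from 6000 nM to 40000 nM.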

Compound 4, half-maximal inhibitory concentration: 5620 nM
Compound 4: middle estimate off by 3.6-fold (0.55 log units), on the high side; the whole stated range lies above it.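

In this assay the added methoxy, ortho to a methoxy group, gives an at least 3.5-fold lower number from compound 3 to compound 4 (0.55 log units; beyond the scatter) and so matters on this core. With that methoxy in place the iodo matters too: there is an at least 3.5-fold lower number from compound 2 to compound 4 (0.55 log units; beyond the scatter) when iodo replaces amino and an at least 3.5-fold lower number from compound 1 to compound 4 (0.55 log units; beyond the scatter) when iodo replaces nitro. Each size is only a minimum, since the other compounds stay at a limit: the limit of > 20000 nM in this assay, at which 3 of the 4 values shown sit.

On these data alone, whether bromo or chloro in place of the iodo, or ethoxy in place of the added methoxy, would keep this activity stays open.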